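A few compounds are considered here, and "the series" means these few. Any claim that something is new, unique, unknown or untested is made for them only; others in the source may bear on it.

- Compound 1 `Nc1ccccc1NC(=O)c1ccc(Cn2cnc3c(Nc4ccccc4)nc(Cl)nc32)cc1`: 2920 nM
- Compound 2 `Nc1ccccc1NC(=O)c1ccc(Cn2cnc3c(Nc4ccc(-c5ccccn5)cc4)nc(Cl)nc32)cc1`: > 20000 nM, a limit of the assay and not a number

Among the compounds with values here, in a functional assay on HeLa cells (Homo sapiens) for antiproliferative activity, read by CCK-8 assay, with a stated time of 72 h (on this read-out higher numbers stand for weaker inhibition and lower numbers for stronger inhibition), compound 1 gives 2920 nM, the only true number so far. Compound 3 `CC1CCN(c2nc(Cl)nc3c2ncn3Cc2ccc(C(=O)Nc3ccccc3N)cc2)CC1` carries 4-methylpiperidin-1-yl in place of anilino on an aromatic carbon. Within the data shown here, the sole measured step, an at least 6.8-fold higher number from compound 1 to compound 2 (0.83 log units; beyond the scatter), puts pyridin-2-yl in place of hydrogen on an aromatic carbon of that anilino group. It lies beyond the scatter, but it adds to the group rather than replacing it, so it bears only loosely. A small rise in the number is therefore expected, probably within the scatter, and the expected step is a 1.2-fold higher number from compound 1 to compound 3 (0.08 log units; within the scatter). For compound 3 the estimated value is 3500 nM, with an expected range from 800 nM to 15000 nM.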

Compound 3, half-maximal inhibitory concentration: 4500 nM
Estimate against measurement, compound 3: 1.3-fold (0.11 log units) below, within the range that was stated.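

In this assay the exchange of anilino for 4-methylpiperidin-1-yl at this position gives a 1.5-fold higher number from compound 1 to compound 3 (0.19 log units; within the scatter), so the two compounds cannot be told apart. Within the data shown here, this single pair shows that the value holds without the aromatic ring and the hydrogen-bond donor of anilino, which the earlier compounds could not show, since they all kept that group. Nothing in the data shown explains this result. On these data alone, whether morpholine, a smaller amine such as dimethylamino, or a carboxylic acid on the piperidine ring would give a similar value remains open.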